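Adding a second aromatic ring to compound 2

The compounds below may be only part of what the source reports. "The series", "measured", "known", "first", "only" and "open" are said of these compounds alone.

Three related compounds have been read in an ADME assay on MRC5 cells (Homo sapiens) for cytotoxicity, read by fluorescence, with a stated time of 72 h (a lower number here means a stronger inhibitor, a higher number a weaker inhibitor), so far. There compound 1 (`CC1(COCc2ccc(OC(F)(F)F)cc2)Cn2cc([N+](=O)[O-])nc2O1`) gives 60000 nM as a measured number. Compound 2 (`CC1(COc2ccc(F)cc2)Cn2cc([N+](=O)[O-])nc2O1`) reads > 64000 nM and that value is a limit of the assay, so compound 2 has no exact number. Compound 3 (`O=[N+]([O-])c1cn2c(n1)O[C@@H](COc1ccc(-c3ccc(F)cc3)nc1)C2`) reads > 64000 nM and that value is also a limit. The common mark of the set is the limit of > 64000 nM in this assay, at which 2 of the 3 values shown sit, and compound 2 stands at it.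

Compound 4 (`CC1(COc2ccc(-c3ccc(C(F)(F)F)cc3)cc2)Cn2cc([N+](=O)[O-])nc2O1`) takes 4-(trifluoromethyl)phenyl in place of fluoro on an aromatic carbon of compound 2 (4-(trifluoromethyl)phenyl in place of fluoro on an aromatic carbon) and keeps the rest of the structure. Going by the values given here, no two measured compounds differ in one place only, so the size of this change rests on indirect comparison. Compound 3, which also carries a second aromatic ring, reads > 64000 nM as a limit. Compound 1 shows a number at 60000 nM with a longer side chain. A small step towards stronger inhibition is therefore expected, estimated as an at least 1.6-fold lower number from compound 2 to compound 4 (0.20 log units; that floor lies within the scatter) and possibly no larger than the scatter. For compound 4 the estimate in this assay is 40000 nM with an expected range from 15000 nM to 64000 nM and a real chance of another limit.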

Compound 4, half-maximal inhibitory concentration: > 64000 nM
Compound 4 gave a limit, no number; the forecaster's own chance of this, stated with the estimate: 45%; middle value at least 1.6-fold (0.20 log units) away from the limit.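

In this assay compound 4 reads > 64000 nM, which is a limit and not a number. Compound 2 also stands at a limit, so no step can be read from compound 2 to compound 4. The compounds shown leave open whether 4-(trifluoromethyl)phenyl in place of fluoro shifts the reading in this assay at all.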